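The source may report more compounds than this note shows. Statements on the series, on what has been measured and on what is new or still open speak of the compounds shown alone.

Measured compounds:
compound 1 `Cc1nc(-c2ccccc2NCC2=NCCN2)cs1`, in a functional assay for activation of Alpha-1B adrenergic receptor (Homo sapiens), read by calcium flux (a higher number here means that more compound is needed for the effect, a lower number that less compound is needed), compound 1 gives 69.2 nM
compound 2 `Cc1ccc(-c2ccccc2NCC2=NCCN2)o1`, in this assay compound 2 gives 46.8 nM

Compound 2 holds the lowest of the two numbers, with compound 1 nearest and the difference within the scatter: a 1.5-fold lower number from compound 1 to compound 2 (0.17 log units; within the scatter). Compound 3 `CCO/N=C(\C)c1ccccc1NCC1=NCCN1` carries a group of 6 heavy atoms (4 carbon, 1 nitrogen, 1 oxygen; no ring) in place of a group of 6 heavy atoms (5 carbon, 1 oxygen; one five-membered aromatic ring with 1 hetero atom), on an aromatic carbon. Among the compounds with values here, the only measured step exchanged one five-membered aromatic ring for another and stayed within the scatter; it bears on compound 3 only loosely, as a group without a ring now enters where a ring leaves. No comparable ring-to-chain change has been measured in this set. A modest rise in this assay is expected, a 2.4-fold higher number from compound 2 to compound 3 (0.37 log units; beyond the scatter). For compound 3 the estimated value is 110 nM, with a range from 35 nM to 350 nM.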

Compound 3, half-maximal effective concentration: < 5020 nM
Compound 3 gave a limit, no number; the forecaster's own chance of this, stated with the estimate: 3%; the middle value lies beyond the limit too.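

In this assay compound 3 gives a limit, < 5020 nM, not a number, so its steps from compound 1 and compound 2 cannot be read. Still open, on these data alone, is how the group without a ring compares with the five-membered aromatic rings.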